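The source may hold more compounds than are shown below. What is called first, only, known or untested is meant among the compounds shown, and "the series" means these compounds.

Measured in a physicochemical assay for solubility, with a stated time of 24 h, tested at 30 mg/mL; a lower number here means a less soluble compound, a higher number a more soluble compound:
- compound 1 `CC(=O)N1CC(CC(=O)NO)(NS(=O)(=O)c2ccc(OCc3cc(C)nc4ccccc34)cc2C)C1` gives 900000 nM
- compound 2 `Cc1cc(COc2ccc(S(=O)(=O)NC3(C(=O)NO)CCCC3)cc2)c2ccccc2n1` gives 200000 nM
- compound 3 `Cc1cc(COc2ccc(S(=O)(=O)NC3(C(=O)NO)CN(C(=O)C(C)C)C3)cc2)c2ccccc2n1` gives 17000000 nM

Of these three, compound 3 stands highest in this assay, and its distance to each of the other two lies beyond the scatter. The next compound to be tested is compound 4 `Cc1cc(COc2ccc(S(=O)(=O)N(C(C)C)C3(C(=O)NO)CN(C(=O)C(C)C)C3)cc2)c2ccccc2n1`, which keeps the whole of compound 3 except for one change: isopropyl in place of hydrogen on a sulfonamide nitrogen here. Among the measured compounds shown here, no two of the measured compounds differ in one place only, so the data hold no direct precedent for this change, and any forecast is a loose one. The measured compounds give only a range to work within. With compound 2 at 200000 nM and compound 3 at 17000000 nM as the two ends of that range, a new compound starting from the top has more room to fall than to rise. A fall beyond the scatter is therefore expected, and the estimated size is a 5.7-fold lower number from compound 3 to compound 4 (0.75 log units; beyond the scatter) in this assay, though a step within the scatter cannot be ruled out. For compound 4 the estimated value is 3000000 nM, with an expected range from 400000 nM to 20000000 nM when the measurement is made.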

Compound 4, solubility: 2200000 nM
Compound 4: middle estimate off by 1.4-fold (0.13 log units), on the high side; measured number inside the range.
By their numbers in this assay, from the lowest: compound 2; then compound 1; then compound 4; then compound 3.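

In this assay, among the compounds shown here, isopropyl in place of hydrogen on a sulfonamide nitrogen gives a 7.7-fold lower number from compound 3 to compound 4 (0.89 log units; beyond the scatter) and this is the first step that can be read for one change alone. The earlier compounds shown here differ from one another in more than one place, so they could show nothing about this nitrogen by itself. Compound 4 now shows that the position is open to substitution without the read-out staying where it was, and that the hydrogen on this nitrogen can be replaced by a branched group of carbon atoms at a cost that lies beyond the scatter.

The series leaves open how the read-out would answer to a methyl, to a longer chain ending in an amine or a carboxylic acid on the same nitrogen, and whether isopropyl would give a step of similar size on the cores of compound 1 and compound 2. The data shown offer no measured account of why the number moves with this change.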